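Ester variation on the cyclohexene dicarboximide series

This account rests on a few compounds, and the source may have more. Where it says the series, first, only, none or still open, it means among the compounds named here.

Measured so far:
compound 1, `COC(=O)c1cc(N2C(=O)C3=C(CCCC3)C2=O)ccc1Cl`: 1620 nM
compound 2, `COC(=O)c1cc(N2C(=O)C3=C(CCCC3)C2=O)c(F)cc1Cl`: 170 nM

In a functional assay on the whole organism with Scenedesmus acutus as the target, with a stated time of 20 h (on this read-out higher numbers stand for weaker inhibition and lower numbers for stronger inhibition), compound 1 gives the highest of the two numbers; its nearest neighbour is compound 2, with a 9.5-fold lower number from compound 1 to compound 2 (0.98 log units; beyond the scatter). That step is the only one measured and concerns fluoro in place of hydrogen on an aromatic carbon, not the ester.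

Compound 3, `CC(C)(C)OC(=O)c1cc(N2C(=O)C3=C(CCCC3)C2=O)ccc1Cl`, differs from compound 1 by tert-butyl in place of methyl on an oxygen next to a carbonyl group. For the measured compounds named here, no measured step touches this oxygen, so the change is estimated to stay within the scatter: for compound 3 the expected step is a 1.0-fold lower number from compound 1 to compound 3 (0.01 log units; within the scatter). Compound 3 is therefore estimated at 1600 nM, with a range from 500 nM to 5000 nM.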

Compound 3, half-maximal inhibitory concentration: > 100000 nM
Compound 3: no number, only a limit; the forecaster's own chance of this, stated with the estimate: 10%; middle value at least 62-fold (1.79 log units) from the limit.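

Replacing methyl with tert-butyl on an oxygen next to a carbonyl group is far from neutral: in this assay the change gives an at least 61-fold higher number from compound 1 to compound 3 (1.79 log units; beyond the scatter), the only step shown at this oxygen. The earlier step concerned an aromatic carbon, so this result adds that the ester alkyl group alone can decide the read-out. Compound 3 gives > 100000 nM, which is a limit and not a number: the limit of > 100000 nM in this assay, at which 1 of the 3 values shown sits.

With only methyl and tert-butyl shown here, the outcome for an ethyl or isopropyl ester or the free carboxylic acid stays open. Also open, on these data alone, is how tert-butyl behaves alongside the fluoro group of compound 2.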